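Removing a Chloro Group From an Allyl-to-Methyl Analogue

This account rests on a few compounds, and the source may have more. Where it says the series, first, only, none or still open, it means among the compounds named here.

Measured so far in a functional assay on Huh-7 cells (Homo sapiens) for cytotoxicity, read by CCK-8 assay, with a stated time of 72 h; a lower number here means a stronger inhibitor, a higher number a weaker inhibitor:
compound 1 `C=CCn1c(=O)/c(=C\c2ccccc2Cl)[nH]c(=O)/c1=C\c1ccccc1OC` gives 6400 nM
compound 2 `C=CCn1c(=O)/c(=C\c2cccc(Cl)c2Cl)[nH]c(=O)/c1=C\c1ccccc1OC` gives 1200 nM
compound 3 `COc1ccccc1/C=c1\c(=O)[nH]/c(=C/c2cccc(Cl)c2Cl)c(=O)n1C` gives 300 nM

Compound 4 `COc1ccccc1/C=c1\c(=O)[nH]/c(=C/c2ccccc2Cl)c(=O)n1C` has not yet been measured. It differs from compound 3 by hydrogen in place of chloro on an aromatic carbon. The same change already occurred once among the measured compounds, from compound 2 to compound 1, where the difference is hydrogen in place of chloro on an aromatic carbon and the step was a 5.3-fold higher number from compound 2 to compound 1 (0.73 log units; beyond the scatter). The two cores differ in that compound 3 arises from compound 2 through (hydrogen in place of vinyl on a saturated chain carbon bound to an aromatic nitrogen), a change that gave a 4.0-fold lower number from compound 2 to compound 3 (0.60 log units; beyond the scatter). Since the place of the chloro removal reads the same in both cases, a step of similar size is expected for compound 4, resting on a 5.3-fold higher number from compound 2 to compound 1 (0.73 log units; beyond the scatter). The expected step is a 5.0-fold higher number from compound 3 to compound 4 (0.70 log units; beyond the scatter). Compound 4 is therefore estimated at 1500 nM, with a plausible range from 700 nM to 3500 nM.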

Compound 4, half-maximal inhibitory concentration: 300 nM
For compound 4 the middle estimate is 5.0-fold (0.70 log units) above the measured one, and the stated range ends above it.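

In this assay, the step from 2,3-dichlorophenyl to 2-chlorophenyl did not carry over from one core to the other, as this core gives no change at the digits printed from compound 3 to compound 4 (within the scatter), unlike the earlier pair: the same change on two cores in this assay, a 5.3-fold higher number (0.73 log units; beyond the scatter) from compound 2 to compound 1 and no change at the digits printed (within the scatter) from compound 3 to compound 4, 5.3-fold (0.73 log units) apart, beyond the scatter of two such steps. The swap of hydrogen for vinyl on the chain bound to the aromatic nitrogen, which gives a 21-fold lower number from compound 1 to compound 4 (1.33 log units; beyond the scatter), likewise depends on the partner group: the same change on two cores in this assay, a 4.0-fold lower number (0.60 log units; beyond the scatter) from compound 2 to compound 3 and a 21-fold lower number (1.33 log units; beyond the scatter) from compound 1 to compound 4, 5.3-fold (0.73 log units) apart, beyond the scatter of two such steps. These four compounds show that the two changes do not simply add up here, but they do not show why, nor whether this holds beyond these compounds.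

Open, from the compounds shown here alone, is how a fluoro or nitrile group in place of the departing chloro would behave. Also open, going by these compounds, is how a longer chain, such as propyl, on the aromatic nitrogen would behave.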